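Taking one methyl off compound 2

The compounds below may be only part of what the source reports. "The series", "measured", "known", "first", "only" and "open" are said of these compounds alone.

In an ADME assay on microsomes from liver (Mus musculus) for metabolic stability, read by LC-MS, using NADPH, with stated times of 10 min and 30 min (a lower number here means slower removal, a higher number faster removal of the compound), compound 1 (`O=C1c2ccc(Cl)cc2CN1c1cccnc1`) gives 76.5 mL/min/kg and compound 2 (`CC1(C)c2cc(Cl)ccc2C(=O)N1c1cccnc1`) gives 25 mL/min/kg. Compound 2 therefore holds the lower of the two numbers, and the gap to compound 1 lies beyond the scatter. Compound 3 (`CC1c2cc(Cl)ccc2C(=O)N1c1cccnc1`) comes from compound 2 by hydrogen in place of methyl on a saturated ring carbon, next to the ring nitrogen. For the measured compounds named here, no measured pair isolates this change, so the size of the step in this assay remains a judgement. A modest rise in the number is expected, close to the edge of the scatter, and no higher than the level of compound 1 at 76.5 mL/min/kg. The expected step is a 1.8-fold higher number from compound 2 to compound 3 (0.26 log units; within the scatter). For compound 3 the estimate is 45 mL/min/kg, with a range of 24 mL/min/kg to 80 mL/min/kg.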

Compound 3, clearance: 66.5 mL/min/kg
Compound 3: the middle estimate sits 1.5-fold (0.17 log units) below what was measured; the measured number falls inside the stated range.
By their numbers in this assay, from the lowest: compound 2; then compounds 3 and 1 (each within the scatter of the next).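

In this assay this saturated ring carbon now reads as two single steps: hydrogen in place of methyl gives a 2.7-fold higher number from compound 2 to compound 3 (0.42 log units; beyond the scatter) and lies beyond the scatter, while methyl in place of hydrogen gives a 1.2-fold lower number from compound 1 to compound 3 (0.06 log units; within the scatter) and lies within it. On these compounds, one methyl on this carbon does not separate from none, and only the two methyls together set a compound apart. Nothing measured here bears on the reason for this difference between the two steps.

Still open, going by these compounds, is whether a larger group on this carbon, such as an ethyl or a hydroxymethyl group, would keep the number in this assay near that of compound 2. Also open, on these data alone, is whether the effect of the two methyls carries over when a phenyl ring stands in place of the pyridin-3-yl group.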